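Methoxy added to a saturated lactone core

The compounds below may be only part of what the source reports. "The series", "measured", "known", "first", "only" and "open" are said of these compounds alone.

The series turns on three measured compounds and one awaiting its number. Compound 1 `COc1ccc2cc(CO)oc(=O)c2c1` carries a methoxy and a hydroxymethyl group on an unsaturated lactone core, and in a functional assay on PC-3 cells (Homo sapiens) for antiproliferative activity, read by sulforhodamine B assay, with a stated time of 48 h (on this read-out higher numbers stand for weaker inhibition of growth and lower numbers for stronger inhibition of growth), compound 1 gives 49.2 ug/mL. Compound 2 `COc1ccc2cc(CCCSc3nnnn3-c3ccccc3)oc(=O)c2c1` keeps the same core but bears a longer side chain ending in a sulfur-linked tetrazole, and in this assay compound 2 gives 145 ug/mL. Compound 3 `O=C1OC(CO)Cc2ccccc21` has a saturated lactone ring, a hydroxymethyl group and no methoxy. For compound 3 only a limit is reported in this assay, namely >= 250 ug/mL, and the value sits at the limit of the assay (the limit of >= 250 ug/mL in this assay, at which 1 of the 3 values shown sits). Compound 4 `COc1ccc2c(c1)C(=O)OC(CO)C2` is the structure yet to be tested; it differs from compound 3 by methoxy in place of hydrogen on an aromatic carbon. Within the data shown here, no two measured compounds differ in a single place, so no step can be read directly from the data. The author expects the step of an at least 1.3-fold lower number from compound 3 to compound 4 (0.14 log units; that floor lies within the scatter) to run toward stronger inhibition, but only by a margin that may stay within the scatter. Compound 4 is therefore estimated at 180 ug/mL, with a range from 60 ug/mL to 250 ug/mL, and a fair chance that the assay again reports only a limit.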

Compound 4, concentration for 50% growth inhibition: 175 ug/mL
For compound 4 the middle estimate is 1.0-fold (0.01 log units) above the measured one; measured number inside the range.
By their numbers in this assay, from the lowest: compound 1; then compounds 2 and 4 (each within the scatter of the next). At a limit, above all of these: compound 3.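

In this assay, the series now holds its first step between compounds that differ in one place, with methoxy in place of hydrogen on an aromatic carbon: an at least 1.4-fold lower number from compound 3 to compound 4 (0.15 log units; that floor lies within the scatter). The change therefore brings a measured number onto the saturated lactone core, and at this position, meta to a fused ring and para to a fused ring, methoxy leaves growth inhibition readable in this assay, although nothing beyond the scatter can be claimed for it. Compound 3 is reported only as a limit, >= 250 ug/mL, so the step is a floor and its true size stays unknown: the limit of >= 250 ug/mL in this assay, at which 1 of the 4 values shown sits.

What the compounds shown leave open is whether another group at this place, such as an ethoxy, a chlorine or an amine, would carry the number further than methoxy does, and whether methoxy on another aromatic carbon would give the same result. On these data alone, all other steps, including any involving compound 1 or compound 2, cannot be read, and the role of the unsaturated lactone core therefore remains untested.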